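The source may report more compounds than this note shows. Statements on the series, on what has been measured and on what is new or still open speak of the compounds shown alone.

Compound 1 `Cn1nccc1-c1cc(C(F)(F)F)ccc1[C@H]1CCOc2cc(S(=O)(=O)Nc3ccncn3)ccc21` holds the higher of the two solubility values recorded here: in a physicochemical assay for solubility (a lower number here means a less soluble compound, a higher number a more soluble compound), compound 1 gives 1180000 nM, whereas compound 2 `O=S(=O)(Nc1ncccn1)c1ccc2c(c1)OCC[C@@H]2c1ccc(C(F)(F)F)cc1-c1ccc(F)cn1` gives 225000 nM, a gap beyond the usual scatter. Compound 3 `Cn1nccc1-c1cc(C(F)(F)F)ccc1[C@H]1CCOc2cc(S(=O)(=O)Nc3nccs3)ccc21` has not yet been measured in this assay; it differs from compound 1 in one place (1,3-thiazol-2-yl in place of pyrimidin-4-yl on a sulfonamide nitrogen). Among the compounds with values here, no measured pair shows this exact change, so its size is unknown. Starting from compound 1's 1180000 nM, a modest fall in this assay is expected, a 2.0-fold lower number from compound 1 to compound 3 (0.29 log units; within the scatter), though the result might also stay within the scatter. Compound 3 is therefore estimated at 600000 nM, with a range from 250000 nM to 1500000 nM.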

Compound 3, solubility: 83000 nM
Beside the measured number, compound 3's estimate is 7.2-fold (0.86 log units) above it; measured number below the stated range.
By their numbers in this assay, from the lowest: compound 3; then compound 2; then compound 1.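

In this assay the group on the sulfonamide nitrogen proves to carry real weight: 1,3-thiazol-2-yl in place of pyrimidin-4-yl gives a 14-fold lower number from compound 1 to compound 3 (1.15 log units; beyond the scatter) and so moves the read-out well beyond the scatter. Within the data shown here, the earlier compounds offered no pair differing in one place, so this is the first size seen for any change, and it rests on this single pair. Nothing at hand bears on the reason for it.
Going by these compounds, whether the change in ring size or the sulfur goes with the fall stays open. So does where a pyridine or oxazole ring on the same nitrogen would fall relative to compound 1 and compound 3.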